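Phenyl for Pyrrolyl on a Cyanoacrylamide Chain

The source may hold more compounds than are shown below. What is called first, only, known or untested is meant among the compounds shown, and "the series" means these compounds.

Compound 1 `N#C/C(=C\c1ccc[nH]1)C(=O)NCc1ccc(Cl)c(Cl)c1` was tested in a functional assay on A2780 cells (Homo sapiens) for inhibition, read by MTT assay, with a stated time of 72 h; on this read-out higher numbers stand for weaker inhibition of growth and lower numbers for stronger inhibition of growth. In this assay compound 1 reaches only > 50000 nM, which is a limit of the assay and not a number, namely (the limit of > 50000 nM in this assay, at which 1 of the 3 values shown sits). Compound 2 `COc1ccc(CNC(=O)/C(C#N)=C/c2ccc(Cl)o2)cc1` gives 9000 nM in this assay. Compound 3 `COc1ccc(CNC(=O)/C(C#N)=C/c2ccoc2)cc1` gives 6000 nM in this assay. Within the data shown here, the one measured step at the same place is a 1.5-fold lower number from compound 2 to compound 3 (0.18 log units; within the scatter). Compound 4 `N#C/C(=C\c1ccccc1)C(=O)NCc1ccc(Cl)c(Cl)c1` differs from compound 1 by phenyl in place of 1H-pyrrol-2-yl on a double-bonded chain carbon bound to a double-bonded chain carbon. Among the measured compounds shown here, since the only comparable step stayed within the scatter, and compound 1 stands at a limit, no step beyond the scatter is expected in this assay. Compound 4 is therefore estimated at 50000 nM, with a range from 15000 nM to 150000 nM. The expected step is a number no higher from compound 1 to compound 4 (the limit leaves the size open).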

Compound 4, concentration for 50% growth inhibition: 49000 nM
Compound 4: middle estimate off by 1.0-fold (0.01 log units), on the high side, within the range that was stated.
By their numbers in this assay, from the lowest: compounds 3 and 2 (each within the scatter of the next); then compound 4. At a limit, above all of these: compound 1.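

In this assay, phenyl in place of 1H-pyrrol-2-yl gives an at least 1.0-fold lower number from compound 1 to compound 4 (0.00 log units; that floor lies within the scatter). Among these compounds, this is the first step read at this place on the core of compound 1, and it shows that exchanging the ring, with the loss of the hydrogen-bond donor, yields a countable number, though no step beyond the scatter is established. Compound 1 stands at a limit of the assay, so the true size of the step stays unknown: the limit of > 50000 nM in this assay, at which 1 of the 4 values shown sits.

Going by these compounds, how a pyridyl or a thienyl group would read at this place remains open. So does whether an amine on the phenyl would move the number.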